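Moving the methyl on the aryl piperazine of compound 3

A few compounds are considered here, and "the series" means these few. Any claim that something is new, unique, unknown or untested is made for them only; others in the source may bear on it.

Compound 3 `CCCc1nc(-c2ccccc2)c(CNCCCN2CCN(c3ccc(C)cc3)CC2)o1` gives 53.9% in an assay on HEK293 cells for inhibition of Voltage-dependent T-type calcium channel subunit alpha-1G (Homo sapiens), read by fluorescence, tested at 10 uM (a higher number here means more inhibition at the concentration tested (going by the name of the read-out), a lower number less inhibition), the highest of the three numbers; compound 2 `CCCc1nc(-c2ccccc2)c(CNCCCN2CCN(c3cccc(C(F)(F)F)c3)CC2)o1` gives 51.6%, a gap within the scatter, while compound 1 `CCCc1nc(-c2ccccc2)c(CNCCCN2CCN(c3ccccc3OC)CC2)o1` gives 41%, with a step of a number 12.9 percentage points higher from compound 1 to compound 3 (beyond the scatter). Compound 4 `CCCc1nc(-c2ccccc2)c(CNCCCN2CCN(c3ccccc3C)CC2)o1` differs from compound 3 by 2-methylphenyl in place of 4-methylphenyl on an amine nitrogen in a ring. Among the measured compounds shown here, no measured pair swaps a 4-methylphenyl for a 2-methylphenyl. For the measured compounds named here, the only bearing steps are a number 10.6 percentage points higher from compound 1 to compound 2 (beyond the scatter) and a number 12.9 percentage points higher from compound 1 to compound 3 (beyond the scatter), both leaving the 2-methoxyphenyl of compound 1, and they give no direct guide to a methyl. Compound 4 is therefore expected to show a small drop of a number 7.9 percentage points lower from compound 3 to compound 4 (within the scatter), near the scatter. The estimate for compound 4 is 46%, within 30% to 60%.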

Compound 4, a percentage reported as inhibition, at one concentration (the size of the read-out at that concentration, not a potency): 54.5%
For compound 4 the middle estimate is 8.5 percentage points below the measured one, and the stated range covers the measured number.
By their numbers in this assay, from the lowest: compound 1; then compounds 2, 3 and 4 (each within the scatter of the next).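

In this assay, the 2-methylphenyl in place of the 4-methylphenyl gives a number 0.6 percentage points higher from compound 3 to compound 4 (within the scatter), so where the methyl sits on this aryl ring does not register in this read-out. The same holds against the 3-(trifluoromethyl)phenyl, with a number 2.9 percentage points higher from compound 2 to compound 4 (within the scatter), while methyl in place of methoxy on an aromatic carbon gives a number 13.5 percentage points higher from compound 1 to compound 4 (beyond the scatter), which ties the lower number of compound 1 to the methoxy rather than to having a group on that carbon. Nothing available explains these numbers.

As far as these compounds go, whether a 2-chlorophenyl or a pyridine ring in place of the phenyl would keep this level remains open.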